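A few compounds are considered here, and "the series" means these few. Any claim that something is new, unique, unknown or untested is made for them only; others in the source may bear on it.

Of the compounds shown here, three from one series have so far been tested in an ADME assay on Huh-7 cells (Homo sapiens) for cytotoxicity; on this read-out higher numbers stand for lower toxicity in this test and lower numbers for higher toxicity in this test. Compound 1 `O=C(O)/C(O)=C/C(=O)c1ccc(OCc2ccccc2)cc1` gives > 100000 nM in this assay, which is a limit of the assay and not a number. Compound 2 `O=C(O)/C(O)=C/C(=O)c1ccc(OCc2ccc(Cl)cc2)cc1` gives > 100000 nM in this assay, again a limit. Compound 3 `O=C(O)/C(O)=C/C(=O)c1ccccc1OCc1ccccc1` gives > 100000 nM in this assay, also a limit. The change between compound 1 and compound 2 is chloro in place of hydrogen on an aromatic carbon, and the step is a step that the two limits leave unreadable from compound 1 to compound 2; the two cores of compound 1 and compound 3 differ, but that difference is not broken down here. Compound 4 `O=C(O)/C(O)=C/C(=O)c1ccccc1OCc1ccc(Cl)cc1` carries the same change relative to compound 3, namely (chloro in place of hydrogen on an aromatic carbon), which applies to a different core. Since all three values sit at the limit of > 100000 nM in this assay, at which 3 of the 3 values shown sit, the step from compound 3 to compound 4 is expected to be a number no higher from compound 3 to compound 4 (the limit leaves the size open) in this assay, with the outcome most likely again being a limit. On that basis compound 4 is estimated to give 100000 nM in this assay, within a range from 50000 nM to 300000 nM.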

Compound 4, half-maximal cytotoxic concentration: > 100000 nM
Compound 4 ended at the assay's limit; the forecaster's own chance of this, stated with the estimate: 85%; the middle value sits exactly at the limit.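

Among the compounds shown here, compound 3 and compound 4 both sit at a limit of the assay, so no size can be read for the step between them, and no new step results: the limit of > 100000 nM in this assay, at which 4 of the 4 values shown sit. The compounds shown leave open whether chloro in place of hydrogen on an aromatic carbon changes the outcome at all in this assay.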